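Fluoro substitution on the aryl lactam core and distribution

A few compounds are considered here, and "the series" means these few. Any claim that something is new, unique, unknown or untested is made for them only; others in the source may bear on it.

Compound 1 `O=C1[C@@H](NS(=O)(=O)c2ccc3cc(Cl)ccc3c2)CCN1c1ccc2c(c1)CCNC2` gives 3.6 L/kg in an in vivo ADME assay on the whole organism (strain Sprague-Dawley) for pharmacokinetics, with Rattus norvegicus as the target; a higher number here means that more of the compound sits outside the plasma, a lower number that more of the compound stays in the plasma. Compound 2 `O=C1[C@@H](NS(=O)(=O)c2ccc3c(Cl)c[nH]c3c2)CCN1c1ccc2c(c1)CCNC2` gives 2.9 L/kg in this assay; the difference between the two cores is not broken down here, and the two numbers lie within the scatter of each other. Compound 3 `O=C1[C@@H](NS(=O)(=O)c2ccc3c(Cl)c[nH]c3c2)CCN1c1ccc2c(c1F)CCNC2` gives 1.5 L/kg, a lower number than compound 1, and the change from compound 2 to compound 3 is fluoro in place of hydrogen on an aromatic carbon, which made a step of a 1.9-fold lower number from compound 2 to compound 3 (0.29 log units; within the scatter). Compound 4 `O=C1[C@@H](NS(=O)(=O)c2ccc3cc(Cl)ccc3c2)CCN1c1cc2c(cc1F)CNCC2` is not yet measured; its change from compound 1 is fluoro in place of hydrogen on an aromatic carbon, the same kind of change, though here the place is para to a fused ring rather than ortho to one. The expectation for compound 4 in this assay is a step of a 1.9-fold lower number from compound 1 to compound 4 (0.28 log units; within the scatter), resting on the step from compound 2 to compound 3 a 1.9-fold lower number from compound 2 to compound 3 (0.29 log units; within the scatter). Compound 4 is estimated at 1.9 L/kg, between 1 L/kg and 3.6 L/kg.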

Compound 4, volume of distribution at steady state: 1 L/kg
Estimate against measurement, compound 4: 1.9-fold (0.28 log units) above; low and high end bracket the measured number.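

In this assay, fluoro in place of hydrogen on an aromatic carbon gives a 3.6-fold lower number from compound 1 to compound 4 (0.56 log units; beyond the scatter). The change lowers the number on both cores, and the size of the step does not differ between them beyond what repeat measurements allow: the same change on two cores in this assay, a 1.9-fold lower number (0.29 log units; within the scatter) from compound 2 to compound 3 and a 3.6-fold lower number (0.56 log units; beyond the scatter) from compound 1 to compound 4, 1.9-fold (0.27 log units) apart, within the scatter of two such steps This supports carrying the change across these two cores, but it rests on one pair per core, with the fluoro at a different place in each, and it does not show why the number falls.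

Open, going by these compounds, is whether chloro, methyl or a nitrile on the same aromatic carbon would move the number in this assay as fluoro does. Also open, on these data alone, is whether a fluoro at a further ring position would do the same.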